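A few compounds are considered here, and "the series" means these few. Any claim that something is new, unique, unknown or untested is made for them only; others in the source may bear on it.

Of the compounds shown here, three have so far been tested in a functional assay on A549 cells (Homo sapiens) for inhibition, read by sulforhodamine B assay, with a stated time of 48 h; a higher number here means that more compound is tolerated, a lower number that less compound is tolerated. Compound 1 `COc1ccc(-c2cc(/C=C/C(=O)c3ccc(N)cc3)[nH]n2)cc1` gives 46900 nM, compound 3 `COc1ccc(-c2cc(/C=C/C(=O)c3ccc(N)cc3)[nH]n2)cc1OC` gives 45200 nM, and compound 2 `COc1ccc(C(=O)/C=C/c2cc(-c3cc(OC)c(OC)c(OC)c3)n[nH]2)cc1OC` gives 15700 nM. Compound 3 arises from compound 1 by a single change, (methoxy in place of hydrogen on an aromatic carbon), and the resulting step of a 1.0-fold lower number from compound 1 to compound 3 (0.02 log units; within the scatter) is small. Compound 2 is built on a different core; how its core differs from that of compound 1 is not broken down here, but its number is lower than those of compound 1 and compound 3 by more than the usual scatter.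

Compound 4 `COc1cc(C(=O)/C=C/c2cc(-c3cc(OC)c(OC)c(OC)c3)n[nH]2)cc(OC)c1OC` has not yet been measured. It arises from compound 2 by methoxy in place of hydrogen on an aromatic carbon. Among the compounds with values here, this is the same kind of change as the one leading from compound 1 to compound 3, though in compound 4 the entering group is also meta to a methoxy group. For compound 4 a similarly small step a 1.0-fold higher number from compound 2 to compound 4 (0.01 log units; within the scatter) is expected, because the measured step of a 1.0-fold lower number from compound 1 to compound 3 (0.02 log units; within the scatter) lay within the scatter. Compound 4 is therefore estimated at 16000 nM in this assay, most likely between 7000 nM and 36000 nM.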

Compound 4, concentration lethal to 50% of the cells: 59200 nM
Compound 4: the middle estimate sits 3.7-fold (0.57 log units) below what was measured; the whole stated range lies below it.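

In this assay, a methoxy group in place of a hydrogen on an aromatic carbon does not behave the same way on the two cores: the same change on two cores in this assay, a 1.0-fold lower number (0.02 log units; within the scatter) from compound 1 to compound 3 and a 3.8-fold higher number (0.58 log units; beyond the scatter) from compound 2 to compound 4, 3.9-fold (0.59 log units) apart, beyond the scatter of two such steps

On the core of compound 2 the change gives a 3.8-fold higher number from compound 2 to compound 4 (0.58 log units; beyond the scatter), so a step measured on the core of compound 1 gave no reliable guide here. Within the data shown here, with only two pairs, this does not show whether the core itself accounts for the gap or the surroundings of the entering group, which in compound 4 is ortho to a methoxy group and meta to another, and it says nothing about any further core.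

The compounds shown leave open whether a different group at this place, such as a hydroxy group, a fluorine atom or an ethoxy group, would also give steps that differ between the two cores. They also leave open whether a methoxy group placed elsewhere on these rings would do the same.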